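A few compounds are considered here, and "the series" means these few. Any claim that something is new, unique, unknown or untested is made for them only; others in the source may bear on it.

Measured compounds:
- compound 1, `CC1(C)CC(NC(=O)Nc2ccccc2)c2cc(Cl)ccc2O1`: "not determined" (no result reported)
- compound 2, `CC1(C)CC(NC(=S)Nc2ccc([N+](=O)[O-])cc2)c2cc(Cl)ccc2O1`: 3000 nM
- compound 3, `CC1(C)CC(NC(=S)Nc2ccccc2Cl)c2cc(Br)ccc2O1`: 17000 nM

Among the compounds with values here, compound 1 has no number of its own in a functional assay on B16-F10 cells (Mus musculus) for inhibition, read by MTT assay, with a stated time of 72 h (on this read-out lower numbers stand for stronger inhibition and higher numbers for weaker inhibition), so its standing cannot be placed against compound 2 or compound 3; those two differ from it at the group joining the two nitrogens and at the aryl ends, and no single-change step between any measured pair is available. Compound 4, `CC1(C)CC(NC(=O)Nc2ccc(Cl)cc2)c2cc(Cl)ccc2O1`, differs from compound 1 by chloro in place of hydrogen on an aromatic carbon, the chloro entering para to a large group on the anilino ring. Within the data shown here, with no measured step for this change, the expected size of the step in this assay is unknown in direction and could be none beyond the scatter. Compound 4 is estimated at 15000 nM, expected within 3000 nM to 80000 nM.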

Compound 4, half-maximal inhibitory concentration: 32000 nM
Compound 4: the middle estimate sits 2.1-fold (0.33 log units) below what was measured; the range from low to high includes it.
By their numbers in this assay, from the lowest: compound 2; then compounds 3 and 4 (each within the scatter of the next).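

In this assay no new step can be read between compound 1 and compound 4. The compounds shown leave open what chloro in place of hydrogen on the anilino ring does to inhibition. No further evidence bears on this result.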